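The compounds below may be only part of what the source reports. "The series", "measured", "known", "first", "only" and "open" are said of these compounds alone.

Of the compounds shown here, three sharing one core have been measured in a physicochemical assay for solubility, in phosphate buffer, with a stated time of 18 h, at pH 7.4; on this read-out higher numbers stand for higher solubility and lower numbers for lower solubility. Compound 1 `COc1ccc(-c2nc(N)n(-c3ncnc4ccccc34)n2)cc1` gives 5000 nM. Compound 2 `COc1cc2c(-n3nc(-c4ccccn4)nc3N)ncnc2cc1O` gives 44000 nM, and compound 3 `CCN(CC)C(=O)COc1cc2c(-n3nc(-c4ccccn4)nc3N)ncnc2cc1OC` gives 42000 nM. Compound 3 thus stands second highest of the three: its nearest neighbour is compound 2, whose number lies within the usual scatter of its own, while compound 1 sits well below it, beyond the scatter. Compound 4 `COc1cc2ncnc(-n3nc(-c4ccccn4)nc3N)c2cc1OCCCNC(=O)C(F)(F)F` has not yet been measured. It differs from compound 3 in a single place: 2-(((trifluoromethyl)carbonyl)amino)ethyl in place of diethylcarbamoyl on a saturated chain carbon bound to an oxygen on an aromatic ring. Among the compounds with values here, no measured pair shows this same change, so the expectation rests on the change alone; a modest drop is expected, a 1.7-fold lower number from compound 3 to compound 4 (0.23 log units; within the scatter), though it may well fall within the scatter. Compound 4 is therefore expected to give 25000 nM, in a range from 8000 nM to 60000 nM.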

Compound 4, solubility: 1000 nM
For compound 4 the middle estimate is 25-fold (1.40 log units) above the measured one, outside the stated range (below it).
By their numbers in this assay, from the lowest: compound 4; then compound 1; then compounds 3 and 2 (each within the scatter of the next).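

This place on the shared core turns out to matter: in this assay, 2-(((trifluoromethyl)carbonyl)amino)ethyl in place of diethylcarbamoyl gives a 42-fold lower number from compound 3 to compound 4 (1.62 log units; beyond the scatter) from this single change. Within the data shown here, until now no measured pair differed in one place, so the size of such a step was unknown. Nothing at hand explains this one.

On these data alone, it remains open whether the step follows the whole 3-(((trifluoromethyl)carbonyl)amino)propyl group or only its trifluoromethyl end. Also open, as far as these compounds go, is how an amine or a carboxylic acid on the same chain would read in this assay for comparison.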